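A few compounds are considered here, and "the series" means these few. Any claim that something is new, unique, unknown or untested is made for them only; others in the source may bear on it.

Working notes on the series. In a functional assay on HepG2 cells (Homo sapiens) for inhibition, read by crystal violet staining, with a stated time of 48 h (on this read-out higher numbers stand for weaker inhibition and lower numbers for stronger inhibition), compound 1 `CCn1c(=O)cc(Cl)[s+]1[O-]` gives > 100000 nM, which is a limit of the assay and not a number. Compound 2 `CCn1c(=O)c(Cl)c(Cl)[s+]1[O-]` in this assay gives > 100000 nM, again a limit rather than a number. Compound 2 differs from compound 1 by chloro in place of hydrogen on an aromatic carbon; the step that the two limits leave unreadable from compound 1 to compound 2 has no readable size because both values rest on (the limit of > 100000 nM in this assay, at which 3 of the 3 values shown sit). Compound 3 `CCCCCCCCCCCCSc1cc(=O)n(CCC(=O)OC)[s+]1[O-]` in this assay gives > 100000 nM, also a limit. The difference between the core of compound 1 and the core of compound 3 is not broken down here.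

Compound 4 `CCCCCCCCCCCCSc1c(Cl)c(=O)n(CCC(=O)OC)[s+]1[O-]` is not yet measured. It differs from compound 3 by chloro in place of hydrogen on an aromatic carbon. This is the same kind of change as that from compound 1 to compound 2, but the surroundings of the place differ: in compound 2 the chloro sits next to the ring atom that bears a chloro group (1 heavy atom) and two ring bonds from the ring atom that bears an ethyl group (2 heavy atoms), whereas in compound 4 it sits next to the ring atom that bears a large group and two ring bonds from the ring atom that bears a 2-(methoxycarbonyl)ethyl group (6 heavy atoms).

Within the data shown here, the earlier step offers no size to carry over, and every value so far sits at the limit of > 100000 nM in this assay, at which 3 of the 3 values shown sit. The step from compound 3 to compound 4 is therefore expected to be about a step that the limit leaves unreadable from compound 3 to compound 4, with the outcome most likely another limit. Compound 4 is estimated at 150000 nM, expected to fall between 40000 nM and 600000 nM.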

Compound 4, half-maximal inhibitory concentration: > 100000 nM
Compound 4 was reported as a limit; the forecaster's own chance of this, stated with the estimate: 85%; the middle value does not contradict the limit.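

In this assay compound 4 gives > 100000 nM, a limit and not a number, and the step from compound 3 to compound 4 cannot be read, since both values rest on a limit: the limit of > 100000 nM in this assay, at which 4 of the 4 values shown sit. The compounds shown leave open whether chloro in place of hydrogen on the aromatic carbon changes inhibition at all, and how compounds 1 to 4 rank against one another.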